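Extending an Alkyl Chain in a Small Antiproliferative Series

A few compounds are considered here, and "the series" means these few. Any claim that something is new, unique, unknown or untested is made for them only; others in the source may bear on it.

Compound 1, `CN(/N=N/c1ccc(C(N)=O)cc1)c1cccs1`: 2.9
Compound 2, `C=CCN(C)/N=N/c1ccc(C(N)=O)cc1`: 3.38
Compound 3, `CCN(C)/N=N/c1ccc(C(N)=O)cc1`: 3.66

Three compounds share one core and differ only at the amine nitrogen. In a functional assay on L1210 cells (Mus musculus) for antiproliferative activity (on this read-out lower numbers stand for lower potency and higher numbers for higher potency (the scale is a negative logarithm)), compound 1 gives 2.9, compound 2 gives 3.38 and compound 3 gives 3.66. Compound 3 holds the highest of the three numbers: the step of a number 0.76 log units higher from compound 1 to compound 3 (beyond the scatter) lies beyond the scatter, while the step of a number 0.28 log units higher from compound 2 to compound 3 (within the scatter) lies within it, so compound 3 and compound 2 cannot be ranked against each other.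

Compound 4, `CCCCN(C)/N=N/c1ccc(C(N)=O)cc1`, has not yet been measured. It differs from compound 3 by ethyl in place of hydrogen on a saturated chain carbon, two bonds along the chain from an amine nitrogen. For the measured compounds named here, the one measured step that alters the chain itself rather than replacing a ring, a number 0.28 log units higher from compound 2 to compound 3 (within the scatter), was small; the steps of a number 0.48 log units higher from compound 1 to compound 2 (beyond the scatter) and a number 0.76 log units higher from compound 1 to compound 3 (beyond the scatter) replace thiophen-2-yl with a chain and bear on this change only indirectly. Going by the values given here, a chain grown by two carbons has no direct precedent here, so the expected step of a number 0.14 log units higher from compound 3 to compound 4 (within the scatter) is kept small, with wide uncertainty. Compound 4 is estimated at 3.8, in a range from 3.3 to 4.3.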

Compound 4, logarithm of the reciprocal of the active concentration, log(1/C): 3.47
The estimate for compound 4 lay 0.33 log units above the measured number; low and high end bracket the measured number.
By their numbers in this assay, from the lowest: compound 1; then compounds 2, 4 and 3 (each within the scatter of the next).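

In this assay, ethyl in place of hydrogen on a saturated chain carbon, two bonds along the chain from an amine nitrogen, gives a number 0.19 log units lower from compound 3 to compound 4 (within the scatter), so this first test of chain length leaves ethyl and butyl on the amine nitrogen unranked. The other two steps place butyl with the other open chains: allyl and butyl cannot be ranked either, at a number 0.09 log units higher from compound 2 to compound 4 (within the scatter), while replacing thiophen-2-yl with butyl gives a number 0.57 log units higher from compound 1 to compound 4 (beyond the scatter), so all three chains stand clear of thiophen-2-yl. Nothing available explains these numbers.

As far as these compounds go, whether a longer chain such as hexyl or octyl would separate from ethyl and butyl remains open. So does the effect of a branched chain such as isopropyl, or of a hydroxyl or an amine at the end of the butyl chain.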